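A few compounds are considered here, and "the series" means these few. Any claim that something is new, unique, unknown or untested is made for them only; others in the source may bear on it.

Compound 1 `O=S(=O)(NCCCNCc1ccc(Cl)c(Cl)c1)c1cc(C(F)(F)F)cc(C(F)(F)F)c1`: 1500 nM
Compound 2 `COc1ccc(CNCCCNS(=O)(=O)c2cc(C(F)(F)F)cc(C(F)(F)F)c2)cc1OC`: 3800 nM

In a functional assay on A2780 cells (Homo sapiens) for inhibition, read by MTT assay, with a stated time of 72 h (a higher number here means a weaker inhibitor of growth, a lower number a stronger inhibitor of growth), compound 1 gives 1500 nM, and compound 2 gives 3800 nM. Compound 2 therefore stands with the highest of the two numbers, the nearest being compound 1, a step of a 2.5-fold higher number from compound 1 to compound 2 (0.40 log units; beyond the scatter) for 3,4-dimethoxyphenyl in place of 3,4-dichlorophenyl on a saturated chain carbon bound to an amine nitrogen.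

Compound 3 `COc1cccc(CNCCCNS(=O)(=O)c2cc(C(F)(F)F)cc(C(F)(F)F)c2)c1` has not yet been tested in this assay. It differs from compound 2 by hydrogen in place of methoxy on an aromatic carbon, read one bond further out as 3,4-dimethoxyphenyl to 3-methoxyphenyl. Among the compounds with values here, no measured step touches this change; the single step from compound 1 to compound 2 swaps both ring substituents at once and only shows that the aryl group moves the number modestly. The step is therefore expected to be small, a 1.3-fold lower number from compound 2 to compound 3 (0.10 log units; within the scatter), with no clear direction. Compound 3 is estimated at 3000 nM, within 1200 nM to 8000 nM.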

Compound 3, concentration for 50% growth inhibition: 1600 nM
Compound 3: middle estimate off by 1.9-fold (0.27 log units), on the high side, and the stated range covers the measured number.
By their numbers in this assay, from the lowest: compounds 1 and 3 (each within the scatter of the next); then compound 2.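

In this assay, hydrogen in place of the methoxy group para to a large group gives a step of its own (a 2.4-fold lower number from compound 2 to compound 3 (0.38 log units; beyond the scatter)), whereas the earlier step changed both ring substituents at once (a 2.5-fold higher number from compound 1 to compound 2 (0.40 log units; beyond the scatter)). Compound 3, with its 3-methoxyphenyl, cannot be told apart from compound 1, with its 3,4-dichlorophenyl (a 1.1-fold higher number from compound 1 to compound 3 (0.03 log units; within the scatter)), so the aryl change from compound 1 to compound 2 is matched in size by this one methoxy group. Nothing measured here accounts for the step.

The compounds shown leave open whether a hydroxy group or a chlorine atom in place of that methoxy group would give a number nearer compound 2 or compound 3. They also leave open whether a longer chain in the shared core would preserve these numbers.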